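From ethyl to propyl: compound 3 to compound 4

This account rests on a few compounds, and the source may have more. Where it says the series, first, only, none or still open, it means among the compounds named here.

Values in an ADME assay on CHO cells (Cricetulus griseus) for cytotoxicity, read by LDH release (on this read-out lower numbers stand for stronger inhibition and higher numbers for weaker inhibition), so far:
- compound 1 `CC(Oc1ccc(Cl)cc1Cl)C(=O)NC(C)c1ccc(F)cc1` gives > 100000 nM as a limit
- compound 2 `CC(Oc1ccc(Cl)cc1Cl)C(=O)NC1(c2ccc(F)cc2)CC1` gives 28000 nM as a number
- compound 3 `CCC(NC(=O)C(C)Oc1ccc(Cl)cc1Cl)c1ccc(F)cc1` gives > 100000 nM as a limit

Compound 3 stands at the limit of > 100000 nM in this assay, at which 2 of the 3 values shown sit, and so has no number of its own. Compound 4 `CCCC(NC(=O)C(C)Oc1ccc(Cl)cc1Cl)c1ccc(F)cc1` differs from compound 3 through methyl in place of hydrogen on a saturated chain carbon, three bonds along the chain from an amide-type nitrogen and an aromatic carbon on a saturated chain carbon, three bonds along the chain from an amide-type nitrogen and an aromatic carbon, which turns ethyl to propyl. The nearest measured change is methyl in place of hydrogen two bonds along the chain, seen in a step that the two limits leave unreadable from compound 1 to compound 3 and giving no usable size. Among the compounds with values here, compound 2 at 28000 nM is the only number in the set, but no single-change step links it to compound 3. No step beyond the scatter is therefore expected in this assay, and no direction can be assigned. The expected change is a number no higher from compound 3 to compound 4 (the limit leaves the size open) in estimate. For compound 4 the estimated value is 100000 nM with an expected range from 40000 nM to 200000 nM and a limit reading is the likeliest outcome.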

Compound 4, half-maximal inhibitory concentration: > 100000 nM
Compound 4 was reported as a limit (the forecaster's own chance of this, stated with the estimate: 75%); the middle value sits exactly at the limit.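

In this assay no new step can be read among compound 1, compound 3 and compound 4, which all sit at one limit: the limit of > 100000 nM in this assay, at which 3 of the 4 values shown sit.

The compounds shown leave open whether ethyl or propyl in place of methyl changes the value at all.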